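The source may report more compounds than this note shows. Statements on the series, on what has been measured and on what is new or still open speak of the compounds shown alone.

In a functional assay on HepG2 cells (Homo sapiens), read by MTT assay, with a stated time of 48 h (on this read-out lower numbers stand for stronger inhibition and higher numbers for weaker inhibition), compound 1 (`CCN(CC)CCCNC(=O)c1ccc(C(CC)(CC)c2ccc(OCC(=O)C(C)(C)C)c(C)c2)n1CC`) gives 180 nM, compound 2 (`CCn1c(C(=O)NCCN)ccc1C(CC)(CC)c1ccc(OCC(=O)C(C)(C)C)c(C)c1`) gives 180 nM and compound 3 (`CCn1c(C(=O)NCCN)ccc1C(CC)(CC)c1ccc(OCC(O)C(C)(C)C)c(C)c1`) gives 176 nM. Compound 3 therefore stands level with the other two, all three lying within the scatter of one another. Compound 4 (`CCn1c(C(=O)N(C)CC(=O)O)ccc1C(CC)(CC)c1ccc(OCC(O)C(C)(C)C)c(C)c1`) differs from compound 3 on a carbonyl carbon, where (carboxymethyl)(methyl)amino takes the place of (2-aminoethyl)amino: (carboxymethyl)(methyl)amino in place of (2-aminoethyl)amino on a carbonyl carbon. Among the compounds with values here, two measured steps bear on this. The nearer one, with amino in place of (diethylamino)methyl on the same chain, shows no change at the digits printed from compound 1 to compound 2 (within the scatter). The other, with 1-hydroxy-2,2-dimethylpropyl in place of (tert-butyl)carbonyl elsewhere on the molecule, shows a 1.0-fold lower number from compound 2 to compound 3 (0.01 log units; within the scatter). Within the data shown here, both are flat, yet compound 1, compound 2 and compound 3 all keep an amino group on that chain, and compound 4 has none, so no measured step covers this change. A move towards a higher number is expected in this assay, though with wide uncertainty, and the estimated step is a 2.6-fold higher number from compound 3 to compound 4 (0.41 log units; beyond the scatter). For compound 4 the estimated value is 450 nM, with an expected range of 120 nM to 2500 nM.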

Compound 4, half-maximal inhibitory concentration: 17100 nM
Estimate against measurement, compound 4: 38-fold (1.58 log units) below; measured number above the stated range.
By their numbers in this assay, from the lowest: compounds 3, 1 and 2 (each within the scatter of the next); then compound 4.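

In this assay, within the data shown here, the group on the carbonyl carbon proves to matter: (carboxymethyl)(methyl)amino in place of (2-aminoethyl)amino gives a 97-fold higher number from compound 3 to compound 4 (1.99 log units; beyond the scatter), the first step beyond the scatter. The earlier compounds shown here showed only that the amino-bearing chain could be shortened and its diethylamino end replaced by amino without a change in the number; this step shows that the series does not stay flat once the chain loses its amino group and takes up a carboxylic acid. Nothing shown accounts for the size of this step.

From the compounds shown here alone, the loss of the amino group, the entry of the carboxylic acid and the methyl on the amide nitrogen all come together here, so their separate shares stay open. A (carboxymethyl)amino group or a (2-aminoethyl)(methyl)amino group at this carbonyl carbon would begin to separate them.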